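This account rests on a few compounds, and the source may have more. Where it says the series, first, only, none or still open, it means among the compounds named here.

Three compounds have been measured in a functional assay on SW480 cells (Homo sapiens) for cytotoxicity, read by MTT assay, with a stated time of 48 h; a higher number here means a weaker inhibitor, a lower number a stronger inhibitor:

compound 1 `C=C[C@@](C)(O)CC[C@H]1C(=C)CC[C@@H]2[C@]1(C)CCC[C@]2(C)C(=O)O`: > 40000 nM, a limit of this assay rather than a number
compound 2 `C=CC(=C)CC[C@@H]1[C@@]2(C)CCC[C@](C)(COC(=O)/C=C\c3ccc(O)c(OC)c3)[C@@H]2CC[C@@]1(C)O`: 17600 nM
compound 3 `C=C1CC[C@@H]2[C@](C)(CCC[C@@]2(C)C(=O)O)[C@H]1CC/C(C)=C/COC(C)=O`: > 40000 nM, again a limit of this assay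

Compound 1 therefore stands at the edge of what this assay reports, with no number of its own; (the limit of > 40000 nM in this assay, at which 2 of the 3 values shown sit), and only compound 2 returns a value at all. The unmeasured compound 4 `C=C1CC[C@@H]2[C@](C)(CCC[C@]2(C)C(=O)O)[C@H]1C/C=C(\C)C=O` differs from compound 1 in a single place: 2-formylprop-1-en-1-yl in place of 2-hydroxy-2-methylbut-3-en-1-yl on a saturated chain carbon bound to a saturated ring carbon. For the measured compounds named here, no step between two measured compounds is available, so there is nothing within this set against which the size of this change can be read, and compound 2 and compound 3 differ from compound 1 in more than one place. The expectation for compound 4 is that it returns a number rather than a limit, so that an at least 2.6-fold lower number from compound 1 to compound 4 (0.42 log units; beyond the scatter) would be a step beyond the scatter toward stronger inhibition, although its exact size cannot be anchored. The estimate for compound 4 in this assay is 15000 nM, expected to lie between 4000 nM and 40000 nM.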

Compound 4, half-maximal inhibitory concentration: > 40000 nM
Compound 4 was reported as a limit (the forecaster's own chance of this, stated with the estimate: 35%); middle value at least 2.6-fold (0.42 log units) away from the limit.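

In this assay compound 4 gives > 40000 nM, a limit and not a number. For the compounds shown here, compound 1 also stands at a limit, so no step from compound 1 to compound 4 can be read. The compounds shown leave open whether 2-formylprop-1-en-1-yl in place of 2-hydroxy-2-methylbut-3-en-1-yl changes inhibition at all: the limit of > 40000 nM in this assay, at which 3 of the 4 values shown sit.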